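Working notes: phenyl for 3-hydroxy-4-methoxyphenyl in compound 2

This account rests on a few compounds, and the source may have more. Where it says the series, first, only, none or still open, it means among the compounds named here.

Measured so far in a functional assay on K562 cells (Homo sapiens) for antiproliferative activity, read by MTT assay, with a stated time of 5 days; a lower number here means a stronger inhibitor, a higher number a weaker inhibitor:
compound 1 `COc1ccc(C(=Cc2ccccc2)C(=O)c2cc(OC)c(OC)c(OC)c2)cc1` gives 4920000 nM
compound 2 `COc1ccc(C=C(C(=O)c2cc(OC)c(OC)c(OC)c2)c2ccc(C)cc2)cc1O` gives 32000 nM

Compound 2 holds the lower number of the two, and the gap to compound 1 lies beyond the scatter. Compound 3 `COc1cc(C(=O)C(=Cc2ccccc2)c2ccc(C)cc2)cc(OC)c1OC` is still to be measured. It carries phenyl in place of 3-hydroxy-4-methoxyphenyl on a double-bonded chain carbon bound to a double-bonded chain carbon. Going by the values given here, no measured pair shows this change alone, since compound 1 and compound 2 differ in more than one place, so the guidance is indirect. Compound 1 does carry phenyl at that place, and its value of 4920000 nM is the higher of the two. On that basis, a step to a higher number in this assay is expected, beyond the scatter. The estimated size is a 16-fold higher number from compound 2 to compound 3 (1.19 log units; beyond the scatter) in the direction of a weaker inhibitor. Compound 3 is expected at 500000 nM with an estimated range from 50000 nM to 5000000 nM when measured.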

Compound 3, half-maximal inhibitory concentration: 2970000 nM
Compound 3: middle estimate off by 5.9-fold (0.77 log units), on the low side; the measured number falls inside the stated range.
By their numbers in this assay, from the lowest: compound 2; then compounds 3 and 1 (each within the scatter of the next).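

In this assay, going by these compounds alone, phenyl in place of 3-hydroxy-4-methoxyphenyl on a double-bonded chain carbon bound to a double-bonded chain carbon gives a 93-fold higher number from compound 2 to compound 3 (1.97 log units; beyond the scatter) and is the first reading of this change alone, showing that this place is highly sensitive and that the large step needs no second change. With phenyl at that place, methyl in place of methoxy on an aromatic carbon gives a 1.7-fold lower number from compound 1 to compound 3 (0.22 log units; within the scatter), so this pair shows no difference beyond the scatter between those two groups. Nothing at hand gives a measured reason for the size of the step from 3-hydroxy-4-methoxyphenyl to phenyl.

The hydroxy and the methoxy of 3-hydroxy-4-methoxyphenyl leave together in this step, so the compounds shown do not tell how much of the loss belongs to either one. Also open, from the compounds shown here alone, is how an amine standing in place of that hydroxy would read in this assay, and whether methyl and methoxy on the aromatic carbon would still read alike with 3-hydroxy-4-methoxyphenyl present.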